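A Dimethylphenyl Swap Without a Hydroxy Group

The source may hold more compounds than are shown below. What is called first, only, known or untested is meant among the compounds shown, and "the series" means these compounds.

In a functional assay on DU-145 cells (Homo sapiens) for inhibition, read by trypan blue exclusion, with a stated time of 96 h (a higher number here means a weaker inhibitor of growth, a lower number a stronger inhibitor of growth), compound 1 `COc1ccc(/C=C(/SCc2ccc(F)cc2)C(=O)c2ccc(Br)cc2)cc1` gives 50000 nM, compound 2 `COc1ccc(/C=C(/SCc2ccc(F)cc2)C(=O)c2ccc(Br)cc2)cc1O` gives 1000 nM, and compound 3 `O=C(/C(=C\c1ccc(Br)cc1)SCc1ccc(F)cc1)c1ccc(Br)cc1` gives 25000 nM. Two steps fix the place of the last of these: a 2.0-fold lower number from compound 1 to compound 3 (0.30 log units; within the scatter), and a 25-fold higher number from compound 2 to compound 3 (1.40 log units; beyond the scatter). It therefore cannot be told apart from the methoxy compound without the hydroxy group, while the hydroxy compound stays clearly lower.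

Compound 4 `Cc1ccc(C)c(/C=C(/SCc2ccc(F)cc2)C(=O)c2ccc(Br)cc2)c1` has not yet been measured. It differs by one swap, 2,5-dimethylphenyl in place of 4-bromophenyl on a double-bonded chain carbon bound to a double-bonded chain carbon.

The large drop so far, a 50-fold lower number from compound 1 to compound 2 (1.70 log units; beyond the scatter), came with hydroxy in place of hydrogen on an aromatic carbon, and the entering group has no hydroxy. The closer precedent is bromo in place of methoxy, a 2.0-fold lower number from compound 1 to compound 3 (0.30 log units; within the scatter), a change at this same ring that stayed small. For the measured compounds named here, no measured compound carries methyl groups, so this rests on very little. In this assay, no shift beyond the scatter is therefore expected, and the estimated step is a 1.3-fold lower number from compound 3 to compound 4 (0.10 log units; within the scatter). Compound 4 is estimated at 20000 nM, with an expected range from 6000 nM to 60000 nM.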

Compound 4, concentration for 50% growth inhibition: 1000 nM
Beside the measured number, compound 4's estimate is 20-fold (1.30 log units) above it; the whole stated range lies above it.
By their numbers in this assay, from the lowest: compounds 2 and 4 (each within the scatter of the next); then compounds 3 and 1 (each within the scatter of the next).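

In this assay, a large drop at this position does not depend on a hydroxy group: 2,5-dimethylphenyl in place of 4-bromophenyl gives a 25-fold lower number from compound 3 to compound 4 (1.40 log units; beyond the scatter) and 2,5-dimethylphenyl in place of 4-methoxyphenyl gives a 50-fold lower number from compound 1 to compound 4 (1.70 log units; beyond the scatter) even though the entering ring has no hydrogen-bond donor. Set against the hydroxy compound, the same ring shows no change at the digits printed from compound 2 to compound 4 (within the scatter) so the two compounds cannot be told apart, and two quite different rings on the double-bonded chain carbon reach one level while 4-bromophenyl and 4-methoxyphenyl stay far weaker. Nothing measured here explains why the dimethylphenyl ring behaves so differently from the 4-bromophenyl ring.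

Still open, from the compounds shown here alone, is whether both methyl groups are needed, or whether a ring with a single methyl group would give the same low number. Also open, going by these compounds, is how far this ring tolerates other additions, such as a hydroxy group placed on the 2,5-dimethylphenyl ring, a longer chain such as ethyl in place of methyl, or an amine or a carboxylic acid.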